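A few compounds are considered here, and "the series" means these few. Any claim that something is new, unique, unknown or untested is made for them only; others in the source may bear on it.

Measured so far in an assay on Prostate gland for inhibition of steroid 5-alpha-reductase (Rattus norvegicus); on this read-out higher numbers stand for weaker inhibition and lower numbers for stronger inhibition: compound 1 `CC(C)=CCn1ccc2cc(/C(C)=C/C(=O)Nc3ccccc3OCCCC(=O)O)ccc21` gives 120 nM; compound 2 `CCC(C)n1ccc2cc(/C(C)=C/C(=O)Nc3ccccc3OCCCC(=O)O)ccc21` gives 67 nM; compound 3 `C/C(=C\C(=O)Nc1ccccc1OCCCC(=O)O)c1ccc2c(ccn2Cc2cccc(C)c2)c1` gives 250 nM.

Compound 3 stands at the highest number of the three, with the step of a 2.1-fold higher number from compound 1 to compound 3 (0.32 log units; beyond the scatter) and the step of a 3.7-fold higher number from compound 2 to compound 3 (0.57 log units; beyond the scatter) both beyond the scatter, whereas the step of a 1.8-fold lower number from compound 1 to compound 2 (0.25 log units; within the scatter) lies within it. Compound 4 `C/C(=C\C(=O)Nc1ccccc1OCCCC(=O)O)c1ccc2c(ccn2Cc2ccc(C(C)(C)C)cc2)c1` differs from compound 3 by 4-(tert-butyl)phenyl in place of 3-methylphenyl on a saturated chain carbon bound to an aromatic nitrogen. Among the measured compounds shown here, no measured step alters the ring of the 3-methylbenzyl group itself; the measured steps only show that this group sits at the weak end of the series. Nothing in the data points to a direction for the change, so the expected step of a 1.2-fold higher number from compound 3 to compound 4 (0.08 log units; within the scatter) is put near zero with a wide range. Compound 4 is thus estimated at 300 nM, between 100 nM and 900 nM.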

Compound 4, half-maximal inhibitory concentration: 170 nM
Compound 4: middle estimate off by 1.8-fold (0.25 log units), on the high side; the measured number falls inside the stated range.
By their numbers in this assay, from the lowest: compounds 2, 1, 4 and 3 (each within the scatter of the next, the first and the last beyond it).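

In this assay, 4-(tert-butyl)benzyl on the aromatic nitrogen in place of 3-methylbenzyl gives a 1.5-fold lower number from compound 3 to compound 4 (0.17 log units; within the scatter), so this larger substituted benzyl group is tolerated without a change that can be read. With a 1.4-fold higher number from compound 1 to compound 4 (0.15 log units; within the scatter) as well, the 3-methylbut-2-en-1-yl and 4-(tert-butyl)benzyl groups cannot be told apart, while a 2.5-fold higher number from compound 2 to compound 4 (0.40 log units; beyond the scatter) keeps sec-butyl apart from 4-(tert-butyl)benzyl. No evidence on hand bears on why these numbers fall as they do.

Still open, from the compounds shown here alone, is whether a plain benzyl, or a benzyl carrying a carboxylic acid or an amine on its phenyl ring, would move the number beyond the scatter. Going by these compounds, a longer straight chain such as n-hexyl on the aromatic nitrogen also remains open.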